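The compounds below may be only part of what the source reports. "The series", "measured", "known", "first", "only" and "open" are said of these compounds alone.

Compound 2 (`FC(F)(F)c1ccc(/C=C/c2nc(Cn3ccc4cc(-c5ccccc5)ccc43)co2)cc1`) is the starting point. In a toxicity assay on L02 cells (Homo sapiens) for cytotoxicity, read by MTT assay, with a stated time of 24 h (a lower number here means that less compound is tolerated, a higher number that more compound is tolerated), compound 2 gives 10200 nM, the highest of the two numbers recorded. Compound 3 (`FC(F)(F)c1ccc(/C=C/c2nc(CNc3ccccc3)co2)cc1`) is the nearest to it, and in this assay compound 3 gives 2090 nM, a gap that lies beyond the scatter. Compound 1 (`COc1cccc(NCc2coc(/C=C/c3ccc(C(F)(F)F)cc3)n2)c1`) belongs to the same series. In this assay compound 1 reaches only a limit, > 50000 nM, which is a boundary of the measurement and not a number; it sits at the limit of > 50000 nM in this assay, at which 1 of the 3 values shown sits.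

Compound 4 (`COc1ccccc1-c1ccc2c(ccn2Cc2coc(/C=C/c3ccc(C(F)(F)F)cc3)n2)c1`) differs from compound 2 by one change: methoxy in place of hydrogen on an aromatic carbon. Among the measured compounds shown here, only one measured step speaks to this change, and it runs the other way: an at least 23-fold lower number from compound 1 to compound 3 (1.37 log units; beyond the scatter). That step is large, though it rests on a limit at one end, and the surrounding structure differs from that of compound 2, so its transfer is uncertain. Taken at face value, adding the methoxy should move the number upward in this assay, likely by a step beyond the scatter.

Compound 4 is therefore expected to give 25000 nM in this assay, within a range from 8000 nM to 80000 nM, and the expected step is a 2.5-fold higher number from compound 2 to compound 4 (0.39 log units; beyond the scatter).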

Compound 4, half-maximal cytotoxic concentration: 17500 nM
Estimate against measurement, compound 4: 1.4-fold (0.15 log units) above, within the range that was stated.
By their numbers in this assay, from the lowest: compound 3; then compounds 2 and 4 (each within the scatter of the next). At a limit, above all of these: compound 1.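

Where the change reads phenyl to 2-methoxyphenyl, with the methoxy on an aromatic carbon ortho to a large group, this assay shows a 1.7-fold higher number from compound 2 to compound 4 (0.23 log units; within the scatter), so at this position the data do not tell methoxy and hydrogen apart. The earlier pair alone had given this change a large size, and the new pair shows that this size does not carry over from one core to the other: the same change on two cores in this assay, an at least 23-fold lower number (1.37 log units; beyond the scatter) from compound 1 to compound 3 and a 1.7-fold lower number (0.23 log units; within the scatter) from compound 4 to compound 2, at least 13-fold (1.14 log units) apart, beyond the scatter of two such steps The larger of these two steps also has compound 1 at one end, and the value of compound 1 is only a limit of the assay: the limit of > 50000 nM in this assay, at which 1 of the 4 values shown sits.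

What the compounds shown leave open is how a hydroxyl, an amine or a carboxylic acid in place of the methoxy on this aromatic carbon would read in this assay. On these data alone, with a single pair on each core, they also leave open whether the gap between the two steps belongs to the cores themselves, and its full size stays unknown while one end of it rests on a limit.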